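Dropping a Methyl Group: From Compound 2 to Compound 4

The source may report more compounds than this note shows. Statements on the series, on what has been measured and on what is new or still open speak of the compounds shown alone.

Of the compounds shown here, three have been measured so far. Compound 1 `Cc1cccc(NC(=O)CN2CCC(c3ccccc3C#N)CC2)c1` gives 8 nM in a functional assay on HEK293 cells for agonist activity at D(4) dopamine receptor (Homo sapiens), read by FLIPR; on this read-out higher numbers stand for an effect only at larger amounts of compound and lower numbers for an effect already at smaller amounts. For the measured compounds named here, compound 3 `Cc1cccc(NC(=O)CN2CCC(c3cccc(C#N)n3)CC2)c1` gives 36 nM, and the only single-point step recorded is a 4.5-fold higher number from compound 1 to compound 3 (0.65 log units; beyond the scatter), which concerns the group on the saturated ring carbon. Compound 2 `Cc1cc(NC(=O)CN2CCC(c3cccc[n+]3[O-])CC2)ccc1F` gives 18 nM; its number stands second of the three, within the usual scatter of compound 3 and beyond the scatter from compound 1.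

Compound 4 `O=C(CN1CCC(c2cccc[n+]2[O-])CC1)Nc1ccc(F)cc1` is not yet measured. It differs from compound 2 in one place: hydrogen in place of methyl on an aromatic carbon. Going by the values given here, no measured step touches this part of the shared core; the step from compound 1 to compound 3 changes the group on the saturated ring carbon and says nothing about the methyl group on the anilide ring. There is therefore no basis in the data for expecting a shift beyond the scatter, and the expected step of a 1.1-fold higher number from compound 2 to compound 4 (0.05 log units; within the scatter) is accordingly close to none. On that footing compound 4 is estimated at 20 nM in this assay, with a range from 6 nM to 70 nM to cover the uncertainty of an untested change.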

Compound 4, half-maximal effective concentration: 85 nM
The estimate for compound 4 lay 4.3-fold (0.63 log units) below the measured number; measured number above the stated range.
By their numbers in this assay, from the lowest: compound 1; then compounds 2 and 3 (each within the scatter of the next); then compound 4.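

Taking away the methyl group, which turns 4-fluoro-3-methylphenyl into 4-fluorophenyl, gives in this assay a 4.7-fold higher number from compound 2 to compound 4 (0.67 log units; beyond the scatter), a change that lies beyond the scatter. For the compounds shown here, this is the first measured step on this side of the molecule, and it shows that a single carbon on this aromatic ring, ortho to a fluoro group and meta to a large group, registers on this read-out: with everything else held the same, compound 2, which carries the methyl group, acts at smaller amounts than compound 4, which carries hydrogen. No measurement at hand accounts for the size of this step.

The compounds shown leave open whether the methyl group is special at this carbon or whether an ethyl group, a chloro group or a methoxy group would give a number like that of compound 2. They also leave open whether the same step would appear with the 2-cyanophenyl group of compound 1 on the saturated ring carbon, since this single pair gives the change in only one setting.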